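The compounds below may be only part of what the source reports. "The series", "measured", "known", "first", "only" and "open" are said of these compounds alone.

Measured so far:
compound 1, `C=CCc1cc(CN(C)C(C)C)c(O)c(-c2cc(CC=C)c(O)c(CN(C)C(C)C)c2)c1`: 4.1%
compound 2, `C=CCc1cc(-c2ccc(O)c(CC=C)c2)c(O)c(C(c2cc(OC)c(OC)c(OC)c2)N2CCCC2)c1`: 43%
compound 3, `C=CCc1cc(-c2ccc(O)c(CC=C)c2)c(O)c(C(c2cc(OC)c(OC)c(OC)c2)N2CCCCC2)c1`: 56.4%

In an assay on isolated protein for inhibition of Maltase-glucoamylase (Homo sapiens), with stated times of 15 min and 10 min, tested at 64 uM (on this read-out lower numbers stand for less inhibition and higher numbers for more inhibition at the one concentration tested (going by the name of the read-out)), compound 3 stands highest of the three numbers, with compound 2 nearest and compound 1 furthest, both gaps beyond the scatter. Compound 4, `C=CCc1cc(-c2ccc(O)c(CC=C)c2)c(O)c(C(c2cc(Cl)cc(Cl)c2)N2CCCCC2)c1`, differs from compound 3 in one place: 3,5-dichlorophenyl in place of 3,4,5-trimethoxyphenyl on a saturated chain carbon bound to an amine nitrogen in a ring and an aromatic carbon. Going by the values given here, the only measured step, a number 13.4 percentage points higher from compound 2 to compound 3 (beyond the scatter), changed the ring on the amine nitrogen, not the aryl group that is swapped here, so no measured step bears directly on this change. Without a guide, only a step of uncertain direction and modest size can be expected. The step from compound 3 to compound 4 is expected to be a number 11.4 percentage points lower from compound 3 to compound 4 (beyond the scatter). Compound 4 is therefore estimated at 45%, within a range from 22% to 68%.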

Compound 4, a percentage reported as inhibition, at one concentration (the size of the read-out at that concentration, not a potency): 87.7%
Beside the measured number, compound 4's estimate is 42.7 percentage points below it, and the stated range ends below it.
By their numbers in this assay, from the lowest: compound 1; then compound 2; then compound 3; then compound 4.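

In this assay the aryl group on a saturated chain carbon bound to an amine nitrogen in a ring and an aromatic carbon proves to be a strong lever: 3,5-dichlorophenyl in place of 3,4,5-trimethoxyphenyl gives a number 31.3 percentage points higher from compound 3 to compound 4 (beyond the scatter) and makes a large step. The earlier compounds shown here showed only a modest step, from changing the ring on the amine nitrogen. Nothing available explains this gain.

The compounds shown leave open whether the chlorines themselves matter, which a plain phenyl or 3,5-difluorophenyl at this place could test. As far as these compounds go, whether the gain also holds with pyrrolidin-1-yl on that carbon remains open too.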